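The source may report more compounds than this note shows. Statements on the series, on what has been measured and on what is new or still open speak of the compounds shown alone.

Compound 1 `Oc1cccc(-c2cc(-c3ccccc3O)cc(-c3ccccc3O)n2)c1`: 3390 nM in a functional assay on HCT-15 cells (Homo sapiens) for cytotoxicity, read by CCK-8 assay, with a stated time of 4 days; on this read-out higher numbers stand for weaker inhibition and lower numbers for stronger inhibition
Compound 2 `Oc1ccc(-c2cc(-c3ccccc3O)nc(-c3ccccc3O)c2)cc1`: > 50000 nM in this assay

Compound 2 stands at the limit of > 50000 nM in this assay, at which 1 of the 2 values shown sits, which is a limit of the assay and not a number. Compound 3 `Oc1ccc(-c2cc(-c3cccc(O)c3)nc(-c3ccccc3O)c2)cc1` rearranges compound 2 through (3-hydroxyphenyl in place of 2-hydroxyphenyl on an aromatic carbon); the change is 3-hydroxyphenyl in place of 2-hydroxyphenyl on an aromatic carbon. Compound 1, which carries a 3-hydroxyphenyl group, gives 3390 nM in this assay. On that basis the step from compound 2 to compound 3 is expected to be an at least 1.6-fold lower number from compound 2 to compound 3 (0.22 log units; that floor lies within the scatter), toward stronger inhibition, though its size stays uncertain. Compound 3 is estimated at 30000 nM, between 8000 nM and 120000 nM.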

Compound 3, half-maximal inhibitory concentration: 5830 nM
Compound 3: the middle estimate sits 5.1-fold (0.71 log units) above what was measured; measured number below the stated range.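

Compound 2 sits at a limit of the assay and not at a number: the limit of > 50000 nM in this assay, at which 1 of the 3 values shown sits. Even so, placing 3-hydroxyphenyl in place of 2-hydroxyphenyl next to the ring nitrogen gives an at least 8.5-fold lower number from compound 2 to compound 3 (0.93 log units; beyond the scatter) in this assay, so at this position the place of the hydroxyl on the ring matters. With a 3-hydroxyphenyl group present, exchanging one hydroxyphenyl group for another gives a 1.7-fold higher number from compound 1 to compound 3 (0.24 log units; within the scatter), which makes no clear difference. The compounds shown leave open whether the hydroxyl itself is needed at this position, as a methoxyphenyl or aminophenyl group there would show.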